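Swapping Cyclopropyl for Furan-2-yl on an Ester Chain

A few compounds are considered here, and "the series" means these few. Any claim that something is new, unique, unknown or untested is made for them only; others in the source may bear on it.

Three compounds have been measured in an assay on CHO cells for inhibition of metabotropic glutamate receptor 1 (Rattus norvegicus); a lower number here means a stronger inhibitor, a higher number a weaker inhibitor:
Compound 1, `CCCOC(=O)c1[nH]c(COC(C)=O)c(C(=O)OC(C)(C)C)c1C`, gives 2700 nM.
Compound 2, `Cc1c(C(=O)OC(C)C(C)(C)C)c[nH]c1C(=O)OC(C)CN(C)C`, gives 390 nM.
Compound 3, `Cc1c(C(=O)OC(C)(C)C)c[nH]c1C(=O)OCC1CC1`, gives 48 nM.

Compound 3 stands at the lowest number of the three. Its nearest neighbour is compound 2, whose number is higher by a margin beyond the scatter, and compound 1 lies further away still, also beyond the scatter. On these numbers compound 3 is the strongest inhibitor of the set.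

Compound 4, `Cc1c(C(=O)OC(C)(C)C)c[nH]c1C(=O)OCc1ccco1`, has not yet been measured in this assay. It differs from compound 3 in one place: furan-2-yl in place of cyclopropyl on a saturated chain carbon bound to an oxygen next to a carbonyl group. Read one bond further out, cyclopropylmethoxy becomes (furan-2-yl)methoxy, and the remainder of the molecule is left as it is in compound 3.

Among the compounds with values here, no pair of measured compounds shows this change, so no step is on record for it, and the expectation rests on compound 3 alone. The exchange of a small non-aromatic ring for a small aromatic ring at the same place on the ester chain is expected to shift the number only modestly, if beyond the scatter at all, with a slight lean toward a weaker result. The step from compound 3 to compound 4 is therefore expected to be a 1.4-fold higher number from compound 3 to compound 4 (0.13 log units; within the scatter). For compound 4 the estimate in this assay is 65 nM, with a range from 20 nM to 200 nM.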

Compound 4, half-maximal inhibitory concentration: 1200 nM
Compound 4: middle estimate off by 18-fold (1.27 log units), on the low side; the measured number lies above the stated range.
By their numbers in this assay, from the lowest: compound 3; then compound 2; then compound 4; then compound 1.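

In this assay, furan-2-yl in place of cyclopropyl on a saturated chain carbon bound to an oxygen next to a carbonyl group gives a 25-fold higher number from compound 3 to compound 4 (1.40 log units; beyond the scatter), a large step beyond the scatter. The earlier compounds shown here differ from one another in more than one place, so they could not isolate this position; this step shows that exchanging the ring alone, with the rest of the molecule unchanged, is enough to weaken inhibition substantially. No measurement shown bears on why the two rings differ so much, and the step itself records only the size and direction of the change.

The compounds shown leave open whether the weaker result goes with furan-2-yl in particular or extends to other aromatic rings at this place, such as phenyl or thiophen-2-yl, and whether other saturated rings, such as cyclobutyl or cyclopentyl, would match cyclopropyl. They also leave open whether a simple longer chain, such as n-butyl, would be tolerated here, and whether the same exchange would give a step of similar size on a different core.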